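The compounds below may be only part of what the source reports. "The series", "measured", "known", "first", "only" and "open" are said of these compounds alone.

Compound 1, `Cc1noc(-c2nc(C)c3c(c2N)C(=O)N(Cc2ccc(F)cc2)C3=O)n1`: in a physicochemical assay for solubility, using the shake flask method, in simulated intestinal fluid, measured as kinetic solubility, with a stated time of 2 h, at 25 degrees C, at pH 6.5 (a lower number here means a less soluble compound, a higher number a more soluble compound), compound 1 gives < 5000 nM, which is a limit of the assay and not a number.
Compound 2, `Cc1noc(-c2nc(C)c3c(c2N)C(=O)N(Cc2cccc(F)c2)C3=O)n1`: compound 2 gives < 5000 nM, again a limit.
Compound 3, `Cc1noc(-c2nc(C)c3c(c2N)C(=O)N(Cc2ccccc2C(F)(F)F)C3=O)n1`: compound 3 gives < 5000 nM, again a limit.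

Compound 1 thus stands at the assay limit, and the two further values are limits as well; no number places compound 1 relative to its neighbours. The steps a step that the two limits leave unreadable from compound 1 to compound 2, a step that the two limits leave unreadable from compound 1 to compound 3 and a step that the two limits leave unreadable from compound 2 to compound 3 cannot be read, since every value involved sits at the limit of < 5000 nM in this assay, at which 3 of the 3 values shown sit.

Compound 4, `Cc1noc(-c2nc(C)c3c(c2N)C(=O)N(Cc2ccc(SC(F)(F)F)cc2)C3=O)n1`, differs from compound 1 by (trifluoromethyl)sulfanyl in place of fluoro on an aromatic carbon. Among the measured compounds shown here, none of the measured steps gives a readable size for any change on this ring, so no step bears on the change in a way that can be quantified; the only information is that all three measured analogues remain at the limit. For compound 4 the expectation is therefore a value once more at or under the limit, with the step that the limit leaves unreadable from compound 1 to compound 4 expected to be unreadable. Compound 4 is estimated at 1500 nM, within 200 nM to 5000 nM.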

Compound 4, solubility: < 5000 nM
Compound 4: a limit, no number; the forecaster's own chance of this, stated with the estimate: 85%; the middle value is on the limit's open side.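

No new step can be read between compound 1 and compound 4, which both stand at a limit and not at a number: the limit of < 5000 nM in this assay, at which 4 of the 4 values shown sit.

The compounds shown leave open how compound 1, compound 2, compound 3 and compound 4 rank in this assay, and whether any change on this ring gives a readable value.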